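The source may report more compounds than this note shows. Statements on the series, on what has been measured and on what is new or still open speak of the compounds shown alone.

Measured in an ADME assay on RAW264.7 cells (Mus musculus) for cytotoxicity, read by MTT assay; a higher number here means a weaker inhibitor, a lower number a stronger inhibitor:
- Compound 1 `O=C(/C=C/C=C/c1ccccc1)c1ccccc1`: 44300 nM
- Compound 2 `O=C(/C=C/C=C/c1ccccc1)c1ccc(F)cc1`: "not determined" (no result reported)
- Compound 3 `CN(C)c1ccc(/C=C/C=C/C(=O)c2ccccc2)cc1`: > 100000 nM (a limit, not a number)
- Compound 4 `CN(C)c1ccc(/C=C/C=C/C(=O)c2ccc(F)cc2)cc1`: not yet measured

Compound 3 has only the limit of > 100000 nM in this assay, at which 1 of the 3 values shown sits, to show for it. Compound 4 carries fluoro in place of hydrogen on an aromatic carbon and is otherwise the same. For the measured compounds named here, the one measured step, an at least 2.2-fold higher number from compound 1 to compound 3 (0.35 log units; beyond the scatter), is a different change, dimethylamino in place of hydrogen, so it bears on this one only indirectly. Compound 2 would have shown the fluoro change on the core of compound 1, but it has no result. No step beyond the scatter is therefore expected in this assay. The expected step is a number no higher from compound 3 to compound 4 (the limit leaves the size open) and it is only an estimate. For compound 4 the estimated value is 100000 nM with an expected range from 40000 nM to 250000 nM. Going by the values given here, a limit may again be the only outcome for compound 4.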

Compound 4, half-maximal inhibitory concentration: > 100000 nM
Compound 4: only a limit was reported; the forecaster's own chance of this, stated with the estimate: 55%; the middle value sits exactly at the limit.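

For the compounds shown here, compound 3 and compound 4 each give only a limit, not a number, so no step between them can be read: the limit of > 100000 nM in this assay, at which 2 of the 4 values shown sit.

Whether fluoro in place of hydrogen on an aromatic carbon changes the result at all in this assay stays open among the compounds shown.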